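Amide series: cyclopentyl to phenyl on the carbonyl

The source may hold more compounds than are shown below. What is called first, only, known or untested is meant among the compounds shown, and "the series" means these compounds.

Among the measured compounds shown here, compound 3 `Cc1cc(NC(=O)C2CCCC2)nn1Cc1cc(Cl)ccc1OCc1ccccc1` is the anchor of the set: in a physicochemical assay for lipophilicity, at pH 7.4 (on this read-out higher numbers stand for higher lipophilicity and lower numbers for lower lipophilicity), compound 3 gives 3.5, the only plain number among the three measured. Compound 1 `CNC(=O)c1cc(C)n(Cc2cc(Cl)ccc2OCc2ccccc2)n1` reaches the limit of this assay and gives > 3.7. Compound 2 `Cc1cc(C(=O)Nc2ccccc2)nn1Cc1cc(Cl)ccc1OCc1ccccc1` likewise reaches the limit and gives > 3.7. One measured step is a step that the two limits leave unreadable from compound 1 to compound 2. The steps into compound 3 are a number at least 0.20 log units lower from compound 1 to compound 3 (that floor lies within the scatter) and a number at least 0.20 log units lower from compound 2 to compound 3 (that floor lies within the scatter); both rest on the limit of > 3.7 in this assay, at which 2 of the 3 values shown sit, and are floors rather than measured sizes.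

Compound 4 `Cc1cc(NC(=O)c2ccccc2)nn1Cc1cc(Cl)ccc1OCc1ccccc1` differs from compound 3 in one place: phenyl in place of cyclopentyl on a carbonyl carbon. For the measured compounds named here, no measured step swaps these two groups on a carbonyl carbon; what bears on it is only that compound 3 sits under the limit by a margin within the scatter. For compound 4 the expected step in this assay is a number 0.10 log units higher from compound 3 to compound 4 (within the scatter), small and possibly upward, with the limit in reach. The estimate for compound 4 is 3.6, with a range from 3.3 to 3.9.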

Compound 4, distribution coefficient: > 3.7
Compound 4 was reported as a limit; the forecaster's own chance of this, stated with the estimate: 40%; at least 0.10 log units between middle value and limit.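

Among the compounds shown here, this is the first reading of a change on the carbonyl carbon of the amide series: phenyl in place of cyclopentyl gives a number at least 0.20 log units higher from compound 3 to compound 4 (that floor lies within the scatter) in this assay. That figure is a floor and not a measured size, so the swap cannot yet be called larger than the scatter, although its true size may be. Compound 3 remains the only compound in the set with a plain number, the steps from compound 1 and compound 2 to compound 4 cannot be read, and the set offers little room for comparison: the limit of > 3.7 in this assay, at which 3 of the 4 values shown sit.

On these data alone, how far compound 4 lies past its limit remains open. Also open, as far as these compounds go, is whether an aminomethyl or hydroxymethyl group in place of phenyl on a carbonyl carbon would give a value that can be read in this assay.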